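The source may hold more compounds than are shown below. What is called first, only, known or untested is meant among the compounds shown, and "the series" means these compounds.

Compound 1, `CCCCCCCCCCCCCCNC(=O)[C@@H]1CSC(c2ccc(NC(C)=O)cc2)N1`, and compound 2, `CCCCCCCCCCCCCCCCCCNC(=O)[C@@H]1CSC(c2ccc(NC(C)=O)cc2)N1`, share a core and differ only at the end of a long saturated chain. In a functional assay on cells (Homo sapiens) for antiproliferative activity, read by sulforhodamine B assay, with a stated time of 48 h (a higher number here means a weaker inhibitor, a lower number a stronger inhibitor), compound 1 gives 2300 nM, while compound 2 gives 22300 nM. The change between them, (butyl in place of hydrogen on a saturated chain carbon, ten or more bonds along the chain from an amide-type nitrogen), produced a 9.7-fold higher number from compound 1 to compound 2 (0.99 log units; beyond the scatter).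

Compound 3, `CCCCCCCCCCCCNC(=O)[C@@H]1CSC(c2ccc(N)cc2)N1`, carries a different core; how the two cores differ is not broken down here. In this assay compound 3 gives 2200 nM, a number within the scatter of compound 1 and well apart from compound 2.

Compound 4, `CCCCCCCCCCCCCCCCNC(=O)[C@@H]1CSC(c2ccc(N)cc2)N1`, is made from compound 3 by the same change, (butyl in place of hydrogen on a saturated chain carbon, ten or more bonds along the chain from an amide-type nitrogen), at the same place along the chain. The step from compound 3 to compound 4 is expected to resemble the earlier one, because a 9.7-fold higher number from compound 1 to compound 2 (0.99 log units; beyond the scatter) came from this very change on a closely related core, although a single prior example is a thin basis. On that footing, the expected step is a 9.1-fold higher number from compound 3 to compound 4 (0.96 log units; beyond the scatter). Compound 4 is therefore estimated at 20000 nM, most plausibly between 8000 nM and 50000 nM.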

Compound 4, half-maximal inhibitory concentration: 2300 nM
Compound 4: the middle estimate sits 8.7-fold (0.94 log units) above what was measured; the measured number lies below the stated range.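

In this assay, the same butyl extension of the chain gives a 1.0-fold higher number from compound 3 to compound 4 (0.02 log units; within the scatter) on the second core, so the large step seen on the first core does not appear here. The change therefore does not carry over from one of these pairs to the other, and one step on a related core proved a poor guide to the next: the same change on two cores in this assay, a 9.7-fold higher number (0.99 log units; beyond the scatter) from compound 1 to compound 2 and a 1.0-fold higher number (0.02 log units; within the scatter) from compound 3 to compound 4, 9.3-fold (0.97 log units) apart, beyond the scatter of two such steps This does not show that the core alone sets the size of the step, since the two pairs also start from chains of different length, and two pairs cannot separate these two differences.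

The compounds shown leave open whether a longer chain on the core of compound 4 would bring the same weakening seen with compound 2, or whether that weakening belongs to the core of compound 2 alone. They also leave open how either core would respond to a chain ending in an amine or a carboxylic acid.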